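The compounds below may be only part of what the source reports. "The series", "measured", "known", "first", "only" and "open" are said of these compounds alone.

Compound 1 `CCOc1cccc(N2CCNCC2)n1` shows 30 mg/kg in a functional assay on the whole organism with Mus musculus as the target, in the maximal electroshock model, with a stated time of 30 min; on this read-out higher numbers stand for an effect only at larger amounts of compound and lower numbers for an effect already at smaller amounts. Compound 2 `CC(C)Oc1cccc(N2CCNCC2)n1` shows 30 mg/kg in this assay, so compound 1 stands level with compound 2, and the step of no change at the digits printed from compound 1 to compound 2 (within the scatter) lies within the scatter. Compound 3 `c1cc(OCC2CCCCC2)nc(N2CCNCC2)c1` differs from compound 1 by cyclohexyl in place of methyl on a saturated chain carbon bound to an oxygen on an aromatic ring. For the measured compounds named here, the one measured step involved a far smaller group at the same place and gave no change, so at most a modest shift is expected here. Compound 3 is therefore estimated at 30 mg/kg in this assay, within 10 mg/kg to 100 mg/kg, a step of no change at the digits printed from compound 1 to compound 3 (within the scatter).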

Compound 3, minimum effective dose: 30 mg/kg
Estimate against measurement, compound 3: no gap at the digits printed, within the range that was stated.
By their numbers in this assay, from the lowest: compounds 1, 2 and 3 (each within the scatter of the next).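

In this assay, putting cyclohexyl in place of methyl gives no change at the digits printed from compound 1 to compound 3 (within the scatter). So this place, a saturated chain carbon bound to an oxygen on an aromatic ring, accepts not only the single added methyl of compound 2 but also a ring of six carbons, without a shift beyond the scatter. Nothing available explains why the value holds across this change.

All the groups shown here at this place contain only carbon and hydrogen. Going by these compounds, what an amine or a carboxylic acid would do here remains open.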